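Dropping the Chlorobenzyl Group from Compound 2

A few compounds are considered here, and "the series" means these few. Any claim that something is new, unique, unknown or untested is made for them only; others in the source may bear on it.

In a functional assay on PC-3 cells (Homo sapiens) for cytotoxicity, read by WST assay, with a stated time of 24 h (a higher number here means a weaker inhibitor, a lower number a stronger inhibitor), compound 2 `COc1ccc2c(C(=O)/C(C#N)=C/c3cn(Cc4ccc(Cl)cc4)c4ccccc34)c[nH]c2c1` reaches only the limit of the assay, > 50000 nM, so no number is known for it. Compound 1 `N#C/C(=C\c1cn(Cc2ccc(Cl)cc2)c2ccccc12)C(=O)c1c[nH]c2ccccc12` gives the same limit, > 50000 nM. Compound 3 `COc1ccc2[nH]cc(/C=C(\C#N)C(=O)c3c[nH]c4cc(F)ccc34)c2c1` likewise gives only the limit, > 50000 nM. Among the measured compounds shown here, all three share (the limit of > 50000 nM in this assay, at which 3 of the 3 values shown sit), and the single step among them, a step that the two limits leave unreadable from compound 1 to compound 2, is not readable, both ends being limits. Compound 4 `COc1ccc2c(C(=O)/C(C#N)=C/c3c[nH]c4ccccc34)c[nH]c2c1` differs from compound 2 by hydrogen in place of 4-chlorobenzyl on an aromatic nitrogen. For the measured compounds named here, no measured step covers this change, so nothing points to a gain or a loss beyond the scatter. Compound 4 is expected to remain at the limit as well, with an estimated step that the limit leaves unreadable from compound 2 to compound 4. Compound 4 is estimated in this assay at 80000 nM, between 20000 nM and 300000 nM.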

Compound 4, half-maximal inhibitory concentration: > 50000 nM
Compound 4: no number, only a limit (the forecaster's own chance of this, stated with the estimate: 85%); the middle value is on the limit's open side.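

Compound 4 also gives only a limit, so the step between compound 2 and compound 4 cannot be read, as both ends are limits. The compounds shown leave open what removing the 4-chlorobenzyl group changes, and how strongly any of them acts.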